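Swapping the amine substituent on a weak kinase inhibitor

This account rests on a few compounds, and the source may have more. Where it says the series, first, only, none or still open, it means among the compounds named here.

Compound 1 `CO[C@H]1CC[C@@H](CNc2cc(NCc3cnccc3C(F)(F)F)ncc2C#N)CC1` was tested in an assay on isolated protein for inhibition of protein kinase C delta type (Homo sapiens), read by TR-FRET, with a stated time of 2 h (a higher number here means a weaker inhibitor, a lower number a stronger inhibitor), and gave 5000 nM, the highest of the two numbers recorded so far. Compound 2 `N#Cc1cnc(NCc2cncnc2C(F)(F)F)cc1N[C@H]1CC[C@@H](O)CC1` in this assay gave 450 nM, a much lower number, so of the two it is the stronger inhibitor; no single-point comparison between these two is available, so only their values can be set side by side.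

Compound 3 `CC1(C)[C@@H](Nc2cc(NCc3cnccc3C(F)(F)F)ncc2C#N)C[C@@H]1C(N)=O` has not yet been measured. It differs from compound 1 in one place: 3-carbamoyl-2,2-dimethylcyclobutyl in place of (4-methoxycyclohexyl)methyl on a nitrogen on an aromatic ring. The methoxycyclohexylmethyl group is gone, and in its place a four-membered ring carrying a primary amide sits directly on the nitrogen.

Among the measured compounds shown here, with no measured step to lean on, the expectation for this change must stay loose. Still, because compound 2 reaches 450 nM while compound 1 sits at 5000 nM, there is room to improve, and compound 3 is expected to move toward a lower number, by a step estimated as a 5.0-fold lower number from compound 1 to compound 3 (0.70 log units; beyond the scatter). Compound 3 is therefore estimated at 1000 nM, within a range from 200 nM to 4000 nM.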

Compound 3, half-maximal inhibitory concentration: > 10000 nM
Compound 3 ended at the assay's limit; the forecaster's own chance of this, stated with the estimate: 10%; middle value at least 10-fold (1.00 log units) away from the limit.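

Among the compounds shown here, this is the only measured step at this position, on a nitrogen on an aromatic ring, and it shows that 3-carbamoyl-2,2-dimethylcyclobutyl in place of (4-methoxycyclohexyl)methyl brings no gain in this assay, with an at least 2.0-fold higher number from compound 1 to compound 3 (0.30 log units; that floor lies within the scatter). Compound 3 gives > 10000 nM, which is a limit of the assay and not a number. The step is therefore a floor and not a measured size, because compound 3 stands at that limit: the limit of > 10000 nM in this assay, at which 1 of the 3 values shown sits.

The compounds shown leave open which part of the change matters, as the four-membered ring, its two methyl groups and the primary amide all enter together, while the six-membered ring and its methoxy group leave together. Also open, on these data alone, is how the number would read with a carboxylic acid or an amine in place of the primary amide on the four-membered ring, or with a methoxy group on that same ring, any of which would separate the effect of the amide from that of the ring.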